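Moving from a fluorophenyl to a pyridinone ring on compound 3

The compounds below may be only part of what the source reports. "The series", "measured", "known", "first", "only" and "open" are said of these compounds alone.

Compound 1 `CCCCc1nc(=O)c(S(=O)(=O)c2ccc(-c3ccc(F)cc3)cc2)c(O)n1-c1c(OC)cccc1OC` gives 47% in an ADME assay on microsomes from liver (Mus musculus) for metabolic stability, using NADPH, with a stated time of 10 min; on this read-out lower numbers stand for a less stable compound and higher numbers for a more stable compound.
Compound 2 `CCCCc1nc(=O)c(S(=O)(=O)c2ccc(-n3ccccc3=O)cc2)c(O)n1-c1c(OC)cccc1OC` gives 63% in this assay.
Compound 3 `CCCCc1[nH]c(=O)c(S(=O)(=O)c2ccc(-c3ccc(F)cc3)cc2)c(O)c1-c1c(OC)cccc1OC` gives "not determined" (no result reported) in this assay, that is, no result was reported for it.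

For the measured compounds named here, compound 3 therefore stands nowhere on the numbers so far: it shares the sulfonyl biaryl arm of compound 1 but sits on a different core, and that core has no measured value. Compound 4 `CCCCc1[nH]c(=O)c(S(=O)(=O)c2ccc(-n3ccccc3=O)cc2)c(O)c1-c1c(OC)cccc1OC` differs from compound 3 in one place: a group of 7 heavy atoms (5 carbon, 1 nitrogen, 1 oxygen; one six-membered aromatic ring with 1 hetero atom) in place of a group of 7 heavy atoms (6 carbon, 1 fluorine; one six-membered aromatic ring of carbon only), on an aromatic carbon.

The same exchange has been made once before, between compound 1 and compound 2, whose cores are alike. There the step of a number 16 percentage points higher from compound 1 to compound 2 (beyond the scatter) pointed toward a more stable compound. If that step carries over, compound 4 should lie above compound 3 in this assay by a similar modest amount. Going by these compounds, without a number for compound 3, however, only compound 2, which carries the same arm on the other core, gives a place to start, and how the two cores compare is unknown.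

The stability of compound 4 is thus expected near 58%, with a wide range from 28% to 85%.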

Compound 4, percent of the compound remaining: 75%
Compound 4: middle estimate off by 17 percentage points, on the low side, within the range that was stated.
By their numbers in this assay, from the lowest: compound 1; then compound 2; then compound 4.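

For the compounds shown here, no step from compound 3 to compound 4 can be read in this assay, as compound 3 has no number there to compare with compound 4. No measured evidence is available to explain the result for compound 4. Still open, going by these compounds, are what exchanging the 4-fluorophenyl does on this core and how the two cores compare.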